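This account rests on a few compounds, and the source may have more. Where it says the series, first, only, none or still open, it means among the compounds named here.

Working notes on the chalcone series

The shared core carries an aryl amide on one side and a cinnamoyl-type enone on the other. Three compounds have numbers in a functional assay on DLD-1 cells (Homo sapiens) for cytotoxicity, read by resazurin assay, with a stated time of 48 h; a lower number here means that less compound is needed, a higher number that more compound is needed for the effect. Compound 1 `O=C(/C=C/c1ccco1)c1ccc(NC(=O)c2ccccc2)cc1` gives 69000 nM. Compound 2 `Nc1ccc(C(=O)/C=C/c2ccccc2)cc1`, which has a free amine in place of the amide, gives 33000 nM. Compound 3 `O=C(/C=C/c1ccccc1)c1ccc(NC(=O)c2cccs2)cc1` gives 35000 nM and so stands second highest of the three, with compound 2 nearest and compound 1 furthest; both gaps are within the scatter.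

Going by the values given here, the one step that can be read off is a 1.1-fold higher number from compound 2 to compound 3 (0.03 log units; within the scatter), so attaching the thiophene carboxamide left the number where the free amine had it.

The next compound, compound 4 `O=C(/C=C/c1ccccc1)c1ccc(NC(=O)c2ccccc2)cc1`, differs from compound 3 in one place: phenyl in place of thiophen-2-yl on a carbonyl carbon. Among the compounds with values here, no measured step covers this exchange directly. What bears on it is the flat step from compound 2 to compound 3 and the fact that compound 1, which already carries the benzamide on a furan-bearing core, sits within the scatter of compound 3. Neither points to a step beyond the scatter in this assay in either direction.

Compound 4 is therefore expected to give 40000 nM, with a range of 17000 nM to 95000 nM. The estimated step of a 1.1-fold higher number from compound 3 to compound 4 (0.06 log units; within the scatter) is expected to stay within the scatter.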

Compound 4, half-maximal effective concentration: 46000 nM
Estimate against measurement, compound 4: 1.2-fold (0.06 log units) below; the measured number falls inside the stated range.
By their numbers in this assay, from the lowest: compounds 2, 3, 4 and 1 (each within the scatter of the next, the first and the last beyond it).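

In this assay, the exchange on a carbonyl carbon whose other neighbour is the amide-type nitrogen now has a measured step of its own (a 1.3-fold higher number from compound 3 to compound 4 (0.12 log units; within the scatter)), so thiophen-2-yl and phenyl cannot be told apart at this position. Benzoyl on the nitrogen on an aromatic ring also leaves the number within the scatter of the free amine (a 1.4-fold higher number from compound 2 to compound 4 (0.14 log units; within the scatter)), which gives a second acyl group alongside (thiophen-2-yl)carbonyl with no step beyond the scatter (a 1.1-fold higher number from compound 2 to compound 3 (0.03 log units; within the scatter)). The change on the double-bonded chain carbon also has its first one-place reading, and phenyl in place of furan-2-yl stays within the scatter as well (a 1.5-fold lower number from compound 1 to compound 4 (0.18 log units; within the scatter)).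

Still open, on these data alone, is whether any change at these places moves the number beyond the scatter in this assay, for instance a carboxylic acid or a dimethylamino group on the benzoyl ring, or a longer chain between the carbonyl and that ring. No supporting measurement is at hand to say what lies behind these flat steps.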